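The source may hold more compounds than are shown below. What is called first, only, known or untested is meant among the compounds shown, and "the series" means these compounds.

Of the compounds shown here, two of a shared core have been measured in a functional assay on HCC1937 cells (Homo sapiens) for antiproliferative activity, read by CCK-8 assay, with a stated time of 72 h; a lower number here means a stronger inhibitor, a higher number a weaker inhibitor. Compound 1 `COc1ccc(C(=O)Nc2cccc(-c3oc4cc(-c5ccc(F)cc5)ccc4c(=O)c3O)c2)cc1` gives 5490 nM, and compound 2 `Cc1ccccc1C(=O)Nc1cccc(-c2oc3cc(-c4ccc(F)cc4)ccc3c(=O)c2O)c1` gives 9900 nM. The two differ only in the ring attached to the amide carbonyl, and that exchange, a 1.8-fold higher number from compound 1 to compound 2 (0.26 log units; within the scatter), leaves the two numbers within the scatter of each other, so nothing separates compound 2 from compound 1 on the data so far.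

Compound 3 `O=C(Nc1cccc(-c2oc3cc(-c4ccc(F)cc4)ccc3c(=O)c2O)c1)c1ccc(Br)cc1` is the next variation on the same position: 4-bromophenyl in place of 2-methylphenyl on a carbonyl carbon. Among the compounds with values here, the one measured step that bears on this kind of change is the one from compound 1 to compound 2, which swapped one aromatic ring for another at the same carbonyl and produced no shift beyond the scatter. Within the data shown here, with only that step to go on, a change of similar size is expected here, with no clear direction, so the step from compound 2 to compound 3 is estimated at a 1.4-fold lower number from compound 2 to compound 3 (0.15 log units; within the scatter). Compound 3 is therefore expected to give about 7000 nM in this assay, most likely between 2500 nM and 20000 nM.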

Compound 3, half-maximal inhibitory concentration: 8630 nM
For compound 3 the middle estimate is 1.2-fold (0.09 log units) below the measured one, within the range that was stated.
By their numbers in this assay, from the lowest: compounds 1, 3 and 2 (each within the scatter of the next).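

Compound 3 adds a third substituted phenyl ring at the amide carbonyl, and 4-bromophenyl in place of 2-methylphenyl gives a 1.1-fold lower number from compound 2 to compound 3 (0.06 log units; within the scatter) in this assay. It also provides a cleaner comparison than the first pair, since compound 1 and compound 3 differ only in one substituent on the aromatic ring, with bromo in place of methoxy giving a 1.6-fold higher number from compound 1 to compound 3 (0.20 log units; within the scatter). Methoxy, methyl and bromo versions therefore cannot be told apart here, so this position has so far shown no sensitivity to these changes, and no measurement shown offers an explanation.

As far as these compounds go, all three groups on the carbonyl are substituted phenyl rings, so it remains open whether the numbers would hold with a basic amine such as piperidine, a ring bearing a carboxylic acid, or a longer alkyl chain in place of the ring. The rest of the shared core stays constant throughout, so these three compounds say nothing about how much the 4-fluorophenyl group or the ring hydroxyl contributes to the activity.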